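The source may report more compounds than this note shows. Statements on the series, on what has been measured and on what is new or still open speak of the compounds shown alone.

Working notes on the series. In a functional assay on A549 cells (Homo sapiens) for antiproliferative activity, read by sulforhodamine B assay, with a stated time of 48 h (on this read-out lower numbers stand for stronger inhibition and higher numbers for weaker inhibition), compound 1 (`COc1ccc(C(=O)/C=C\Nc2ccc(-c3nc4cc(OC)c(OC)c(OC)c4s3)cc2C)cc1O`) gives 15400 nM and compound 2 (`COc1cc(OC)c2sc(-c3ccc(N/C=C\C(=O)c4cc(OC)c(OC)c(OC)c4)c(C)c3)nc2c1`) gives 14400 nM. Within the data shown here, these two values lie within the scatter of each other, so compound 2 stands level with compound 1 on the numbers so far.

Compound 3 (`COc1cc(C(=O)/C=C\Nc2ccc(-c3nc4cc(OC)c(OC)c(OC)c4s3)cc2C)cc(OC)c1OC`) has not yet been measured. It arises from compound 2 through one change, methoxy in place of hydrogen on an aromatic carbon. The new methoxy sits on a six-membered aromatic ring of carbon only, part of a fused or bridged system of two rings, ortho to two methoxy groups.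

Among the measured compounds shown here, no measured pair differs in one place only, so this change has no direct precedent. For the measured compounds named here, the only guide is the level of compound 2 at 14400 nM. In this assay, no shift beyond the scatter is expected in either direction. The expected change is a 1.1-fold lower number from compound 2 to compound 3 (0.04 log units; within the scatter). Compound 3 is estimated at 13000 nM, with an expected range of 5000 nM to 32000 nM.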

Compound 3, half-maximal inhibitory concentration: 23300 nM
Compound 3: the middle estimate sits 1.8-fold (0.25 log units) below what was measured; the measured number falls inside the stated range.
By their numbers in this assay, from the lowest: compounds 2, 1 and 3 (each within the scatter of the next).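

In this assay, among these compounds, the step at this position, methoxy in place of hydrogen on an aromatic carbon ortho to two methoxy groups, gives a 1.6-fold higher number from compound 2 to compound 3 (0.21 log units; within the scatter) and so stays within the scatter; this is the first one-place reading for this change, and it places compound 3 level with compound 2. The other new comparison, 3,4,5-trimethoxyphenyl in place of 3-hydroxy-4-methoxyphenyl on a carbonyl carbon, gives a 1.5-fold higher number from compound 1 to compound 3 (0.18 log units; within the scatter) and also stays within the scatter, so neither change separates the compounds on this read-out. No measurement at hand accounts for either step.

The compounds shown leave open whether an ethoxy group, a fluorine atom or an amine on the same aromatic carbon would give a step beyond the scatter, since methoxy and hydrogen are the only two groups compared there. They also leave open whether a carboxylic acid or an amine on the phenyl group attached to the carbonyl carbon would move the number away from the level shared by these three compounds.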